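The source may report more compounds than this note shows. Statements on the series, on what has been measured and on what is new or still open speak of the compounds shown alone.

Measured so far in a functional assay on A549 cells (Homo sapiens) for antiproliferative activity, with a stated time of 5 days; on this read-out higher numbers stand for weaker inhibition and lower numbers for stronger inhibition
compound 1 `Cc1ccc(-n2nc(-c3ccc4ccccc4c3)nc2N2C(=O)COC23C=CC(=O)C=C3)cc1` gives 110 nM
compound 2 `Cc1ccccc1-n1nc(-c2cccc3ccccc23)nc1N1C(=O)COC12C=CC(=O)C=C2` gives 130 nM
compound 3 `O=C1C=CC2(C=C1)OCC(=O)N2c1nc(-c2ccc3ccccc3c2Br)nn1-c1ccccc1` gives 100 nM

Compound 2 at 130 nM lies within the usual scatter of both compound 1 and compound 3, so these three values cannot be put in order. The compound to be measured next is compound 4 `Cc1ccc(-n2nc(-c3cccc4ccccc34)nc2N2C(=O)COC23C=CC(=O)C=C3)cc1` which has the same atoms as compound 2, joined differently. The whole change is 4-methylphenyl in place of 2-methylphenyl on an aromatic nitrogen and in words it is 4-methylphenyl in place of 2-methylphenyl on an aromatic nitrogen.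

Going by the values given here, no two measured compounds differ in just one place, so the data show no direct example of what such a change does. The closest hint is indirect. Compound 1 also carries 4-methylphenyl but differs from compound 4 in another place as well, and compound 1 at 110 nM stays within the scatter of compound 2. On that slender evidence, no step beyond the scatter is expected in this assay and no direction can be favoured. The estimated step of a 1.1-fold lower number from compound 2 to compound 4 (0.03 log units; within the scatter) is therefore expected to be too small to read as a real change. For compound 4 the expected value is 120 nM with an estimated range of 50 nM to 280 nM in this test.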

Compound 4, half-maximal inhibitory concentration: 140 nM
For compound 4 the middle estimate is 1.2-fold (0.07 log units) below the measured one; low and high end bracket the measured number.
By their numbers in this assay, from the lowest: compounds 3, 1, 2 and 4 (each within the scatter of the next).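

Going by these compounds alone, putting 4-methylphenyl in place of 2-methylphenyl on the aromatic nitrogen gives a 1.1-fold higher number from compound 2 to compound 4 (0.03 log units; within the scatter) in this assay and is the only direct comparison at this position, so on this naphthalen-1-yl background the two methylphenyl groups cannot be told apart. The second one-place pair, with naphthalen-1-yl in place of naphthalen-2-yl on an aromatic carbon, gives a 1.3-fold higher number from compound 1 to compound 4 (0.10 log units; within the scatter) and adds that this swap, too, on a 4-methylphenyl background, produces no readable change in the number. With both steps inside the scatter, neither place shows any real effect from these particular swaps, and no separate measurement on these compounds bears on the result.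

Both changes exchange groups with identical atom counts, so the compounds shown say nothing about how the number would respond to a truly different group on the phenyl ring, such as an amine, a carboxylic acid or a longer chain in place of the methyl. No compound shown differs from compound 3 in only one place, so what its bromine contributes on the naphthalene group also remains open.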